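Lengthening a Carbamate Chain on an Acid Ceramidase Inhibitor

A few compounds are considered here, and "the series" means these few. Any claim that something is new, unique, unknown or untested is made for them only; others in the source may bear on it.

Compound 1 `CCCCCCNC(=O)n1cc(C)c(=O)[nH]c1=O` and compound 2 `CCCCCCNC(=O)n1cc(CC)c(=O)[nH]c1=O` share one core and differ in a single group, while compound 3 `CCCCCCNC(=O)n1cc(F)c(=O)n(C(=O)OC)c1=O` is built on another core; the difference between the two cores is not broken down here. In an assay on HEK293 cells for inhibition of acid ceramidase (Rattus norvegicus), read by LC-MS, with a stated time of 30 min (on this read-out lower numbers stand for stronger inhibition and higher numbers for weaker inhibition), compound 1 gives 1460 nM and compound 2 gives 733 nM. In this assay compound 3 gives 7 nM, the lowest number of the three, with its steps to both others beyond the scatter. The change from compound 1 to compound 2 is methyl in place of hydrogen on a saturated chain carbon bound to an aromatic carbon; it made a 2.0-fold lower number from compound 1 to compound 2 (0.30 log units; within the scatter).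

Compound 4 `CCCCCCNC(=O)n1cc(F)c(=O)n(C(=O)OCC)c1=O` has not yet been measured. It arises from compound 3 by methyl in place of hydrogen on a saturated chain carbon bound to an oxygen next to a carbonyl group. Going by the values given here, this is the same kind of change as the one from compound 1 to compound 2, but not the same: there the carbon is bound to an aromatic carbon, here to an oxygen next to a carbonyl group. For compound 4 the expected step in this assay is a 1.2-fold lower number from compound 3 to compound 4 (0.07 log units; within the scatter), and that expectation rests on a 2.0-fold lower number from compound 1 to compound 2 (0.30 log units; within the scatter), which stayed within the scatter. Compound 4 is therefore estimated at 6 nM, with a likely range from 2.5 nM to 15 nM.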

Compound 4, half-maximal inhibitory concentration: 12 nM
The estimate for compound 4 lay 2.0-fold (0.30 log units) below the measured number; measured number inside the range.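

In this assay, going from methoxycarbonyl to ethoxycarbonyl on the core of compound 3 gives a 1.7-fold higher number from compound 3 to compound 4 (0.23 log units; within the scatter), so this step alone shows no clear effect. Set beside the earlier step, however, the added methyl does not carry over from one core to the other as a fixed shift: the same change on two cores in this assay, a 2.0-fold lower number (0.30 log units; within the scatter) from compound 1 to compound 2 and a 1.7-fold higher number (0.23 log units; within the scatter) from compound 3 to compound 4, 3.4-fold (0.53 log units) apart, beyond the scatter of two such steps. This comparison rests on a single pair for each core, and the methyl enters at a different place in each pair, so it does not show whether the core or the place accounts for the gap, and it says nothing about the step on any further core.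

The compounds shown leave open how a longer chain, such as propyl or butyl, would read in this assay in place of the ethyl of the ethoxycarbonyl group. Also open, going by these compounds, is what an amine or a carboxylic acid at the end of the chain shared by all four compounds would do.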